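The source may report more compounds than this note shows. Statements on the series, on what has been measured and on what is new or still open speak of the compounds shown alone.

Measured so far:
- compound 1 `CCn1cc(-c2nc3ccccc3[nH]2)c(=O)c2cc(F)c(N3CCNCC3)cc21` — in a functional assay on HeLa cells (Homo sapiens) for cytotoxicity, read by sulforhodamine B assay, with a stated time of 48 h (on this read-out lower numbers stand for stronger inhibition and higher numbers for weaker inhibition), compound 1 gives only a limit, > 10000 nM
- compound 2 `CCn1cc(-c2nc3ccc(N)cc3[nH]2)c(=O)c2cc(F)c(N3CCNCC3)cc21` — in this assay compound 2 gives only a limit, > 10000 nM

Both entries sit at the same boundary of the assay, (the limit of > 10000 nM in this assay, at which 2 of the 2 values shown sit), so neither is a number. Among the measured compounds shown here, the one step between measured compounds, a step that the two limits leave unreadable from compound 1 to compound 2, therefore cannot be read: amino in place of hydrogen on an aromatic carbon may have moved the read-out in either direction behind that boundary. Compound 2 stands at the edge of the measured range, with no position relative to compound 1 that the two limits allow to state.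

Compound 3 `CCn1cc(-c2nc3ccc(N)cc3[nH]2)c(=O)c2cc(F)c(N3CCN(C)CC3)cc21` differs from compound 2 by methyl in place of hydrogen on an amine nitrogen in a ring. For the measured compounds named here, no measured step covers a change at this ring nitrogen, and the single step available is itself unreadable, so there is no measured ground for expecting a shift in this assay in either direction. The working expectation is that compound 3 stays at or beyond the boundary where compounds 1 and 2 sit, with a modest chance of a readable number near it. The step this implies, a step that the limit leaves unreadable from compound 2 to compound 3, is expected to be none beyond the scatter. For compound 3 the estimate in this assay is 15000 nM, within 5000 nM to 50000 nM.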

Compound 3, half-maximal inhibitory concentration: > 10000 nM
Compound 3 gave a limit, no number; the forecaster's own chance of this, stated with the estimate: 80%; the middle value does not contradict the limit.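

In this assay compound 3 gives > 10000 nM, a limit and not a number. No new step can be read between compound 2 and compound 3, since all values shown sit at one boundary: the limit of > 10000 nM in this assay, at which 3 of the 3 values shown sit. Still open, on these data alone, is how far compound 1, compound 2 and compound 3 each lie beyond that boundary, and whether amino or methyl changes the read-out at all.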